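This account rests on a few compounds, and the source may have more. Where it says the series, first, only, none or still open, it means among the compounds named here.

In an ADME assay on MT4 cells (Homo sapiens) for cytotoxicity, read by MTT assay, with a stated time of 5 days (a higher number here means that more compound is tolerated, a lower number that less compound is tolerated), compound 3 `Cc1ccccc1NC(=O)CSc1ncnn1-c1ccc(Cl)cc1Cl` gives 106000 nM and compound 1 `O=C(CSc1ncnn1-c1ccc(Cl)cc1Cl)Nc1ccccc1Br` gives 95100 nM which places the two within the scatter of each other. Compound 2 `Cc1ccc(NC(=O)CSc2ncnn2-c2ccc(Cl)cc2Cl)c([N+](=O)[O-])c1` is recorded with > 285000 nM as a limit and not a number. The change to compound 4 `Cc1ccc(NC(=O)CSc2ncnn2-c2ccc(Cl)cc2Cl)c(Br)c1` is 2-bromo-4-methylphenyl in place of 2-methylphenyl on an amide-type nitrogen, counted as 2-bromo-4-methylphenyl in place of 2-methylphenyl on an amide-type nitrogen in the move from compound 3. Within the data shown here, the one measured step that bears on it is a 1.1-fold higher number from compound 1 to compound 3 (0.05 log units; within the scatter) for methyl in place of bromo on an aromatic carbon. On that step alone, a 1.1-fold lower number from compound 3 to compound 4 (0.05 log units; within the scatter) is expected in this assay with no size beyond the scatter and no clear direction. Compound 4 is estimated at 95000 nM with a range from 45000 nM to 200000 nM as the expected span.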

Compound 4, half-maximal cytotoxic concentration: > 184000 nM
Compound 4: a limit, no number; the forecaster's own chance of this, stated with the estimate: 20%; at least 1.9-fold (0.28 log units) between middle value and limit.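

In this assay compound 4 is recorded as a limit and not a number (> 184000 nM). Placing 2-bromo-4-methylphenyl in place of 2-methylphenyl on an amide-type nitrogen gives a floor (an at least 1.7-fold higher number from compound 3 to compound 4 (0.23 log units; that floor lies within the scatter)), and a methyl group added to the aromatic ring gives another (an at least 1.9-fold higher number from compound 1 to compound 4 (0.28 log units; that floor lies within the scatter)). Neither floor shows a step beyond the scatter, and the step between the two limits, from compound 2 to compound 4, cannot be read.

As far as these compounds go, the true size of both steps remains open. Also open, from the compounds shown here alone, is whether an amine or a carboxylic acid on that aromatic ring would give a number rather than a limit.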